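The source may hold more compounds than are shown below. What is called first, only, known or untested is meant among the compounds shown, and "the series" means these compounds.

Working notes on the series, values from a functional assay on THP-1 cells (Homo sapiens) for inhibition; a lower number here means a stronger inhibitor, a higher number a weaker inhibitor:

- compound 1 `O=C1C[C@H](NC(=O)[C@@H]2COC[C@@H]3CCCC[C@H](NC(=O)c4cc5ccccc5s4)C(=O)N32)C(O)O1`: 178 nM
- compound 2 `O=C1C[C@H](NC(=O)[C@@H]2CN(C(=O)OCc3ccccc3)C[C@@H]3C/C=C\C[C@H](NC(=O)c4ccccc4)C(=O)N32)C(O)O1`: 125 nM
- compound 3 `O=C1C[C@H](NC(=O)[C@@H]2CN(C(=O)Nc3ccccc3)C[C@@H]3CCCC[C@H](NC(=O)c4ccccc4)C(=O)N32)C(O)O1`: 1690 nM

Compound 1 and compound 2 lie within the scatter of each other, so no order can be drawn between them. Compound 3 stands well beyond the scatter from compound 1, on the weaker side, and compound 1 therefore sits in the stronger part of this small set.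

The next compound is compound 4 `O=C1C[C@H](NC(=O)[C@@H]2COC[C@@H]3CCCC[C@H](NC(=O)c4nccc5ccccc45)C(=O)N32)C(O)O1`, which has isoquinolin-1-yl in place of 1-benzothiophen-2-yl on a carbonyl carbon. The rest of the structure of compound 1 is kept. The measured compounds differ from one another in more than one place, so none of them shows what a change at this carbonyl alone does. The expectation therefore starts from compound 1 at 178 nM, and no direction is favoured. The estimated step of a 1.1-fold higher number from compound 1 to compound 4 (0.05 log units; within the scatter) is expected to stay within the scatter. The range is kept wide, as the three measured compounds already reach from compound 2 at 125 nM to compound 3 at 1690 nM. For compound 4 the estimated value is 200 nM, with an expected range of 60 nM to 700 nM.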

Compound 4, half-maximal inhibitory concentration: 101 nM
Estimate against measurement, compound 4: 2.0-fold (0.30 log units) above; the measured number falls inside the stated range.
By their numbers in this assay, from the lowest: compounds 4, 2 and 1 (each within the scatter of the next); then compound 3.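

In this assay, within the data shown here, the single change on the carbonyl carbon, isoquinolin-1-yl in place of 1-benzothiophen-2-yl, gives a 1.8-fold lower number from compound 1 to compound 4 (0.25 log units; within the scatter), and this is the first comparison that isolates one place. The step lies within the usual scatter, so the two groups cannot be ordered at this position, and a five-membered aromatic ring with sulfur can give way to a six-membered aromatic ring with nitrogen without a readable difference in this assay. Nothing in the data accounts for why the two groups read alike.

The compounds shown leave open whether this position stays as undemanding with a group of a different kind on the carbonyl carbon, such as cyclohexyl, a dimethylamino chain or a carboxylic acid, since both groups compared here are aromatic. On these data alone, compound 2 and compound 3 differ from compound 1 and compound 4 in more than one place, so steps to them cannot be read, and it remains unknown whether the same swap would give a similar result on those other cores.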